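Methoxy addition in a cytotoxicity series

This account rests on a few compounds, and the source may have more. Where it says the series, first, only, none or still open, it means among the compounds named here.

Compound 1 `COc1ccc(-c2nc3cc(C(C)O)ccc3[nH]2)cc1`, compound 2 `COc1ccc(-c2nc3cc(C(C)O)ccc3[nH]2)c(OC)c1` and compound 3 `COc1ccc(-c2nc3cc(/C(C)=N/O)ccc3[nH]2)c(OC)c1` have been run in an ADME assay on BHK-21 cells (Mesocricetus auratus) for cytotoxicity, read by MTT assay; on this read-out higher numbers stand for lower toxicity in this test and lower numbers for higher toxicity in this test. In this assay compound 1 gives > 100000 nM, a limit of the assay and not a number. Compound 2 gives > 100000 nM in this assay, again a limit. Compound 3 gives > 100000 nM in this assay, also a limit. The change from compound 1 to compound 2 is methoxy in place of hydrogen on an aromatic carbon, and the step is a step that the two limits leave unreadable from compound 1 to compound 2. The step that the two limits leave unreadable from compound 2 to compound 3 is equally unreadable. All three results rest on (the limit of > 100000 nM in this assay, at which 3 of the 3 values shown sit). Compound 4 `COc1ccc(-c2nc3cc(/C(C)=N/O)ccc3[nH]2)c(OC)c1OC` is not yet measured. It differs from compound 3 by methoxy in place of hydrogen on an aromatic carbon, the same kind of change as from compound 1 to compound 2, though the place is now ortho to two methoxy groups and meta to a large group rather than ortho to a large group and meta to a methoxy group. The difference between the cores of compound 1 and compound 3 is not broken down here. For compound 4 a step that the limit leaves unreadable from compound 3 to compound 4 is expected, since the earlier step that the two limits leave unreadable from compound 1 to compound 2 could not be read and every value sits at the limit of > 100000 nM in this assay, at which 3 of the 3 values shown sit. Compound 4 is estimated at 150000 nM in this assay, most probably again only a limit.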

Compound 4, half-maximal cytotoxic concentration: > 100000 nM
Compound 4: no number, only a limit; the forecaster's own chance of this, stated with the estimate: 85%; the middle value lies beyond the limit too.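

In this assay compound 4 gives > 100000 nM as a limit of the assay and not a number. No new step can be read from compound 3 to compound 4, as the series stays at one limit: the limit of > 100000 nM in this assay, at which 4 of the 4 values shown sit. The compounds shown leave open whether methoxy in place of hydrogen on an aromatic carbon changes this read-out at all.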